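The source may hold more compounds than are shown below. What is called first, only, known or untested is meant among the compounds shown, and "the series" means these compounds.

Compound 1 `CNC(=O)c1cc(Oc2ccc(NS(=O)(=O)c3ccc(C(C)(C)C)cc3)cc2)ccn1`: > 40000 nM
Compound 2 `O=C(Nc1ccc(Oc2ccnc3ccccc23)cc1)c1cc(C(F)(F)F)cc(C(F)(F)F)c1`: 16000 nM

In a functional assay on PLC-PRF-5 cells (Homo sapiens) for inhibition (a lower number here means a stronger inhibitor, a higher number a weaker inhibitor), compound 1 gives > 40000 nM, which is a limit of the assay and not a number (the limit of > 40000 nM in this assay, at which 1 of the 2 values shown sits). In this assay, among the compounds with values here, compound 2 gives 16000 nM, the only number among the two measured compounds. Compound 3 `O=C(Nc1ccc(Oc2ccnc3c([N+](=O)[O-])cccc23)cc1)c1cc(C(F)(F)F)cc(C(F)(F)F)c1` differs from compound 2 by nitro in place of hydrogen on an aromatic carbon. Within the data shown here, no step between measured compounds is at hand to guide the expectation. The change is a single small group on the shared core, so a shift no larger than the usual scatter, in either direction, is expected, a 1.3-fold lower number from compound 2 to compound 3 (0.12 log units; within the scatter). Compound 3 is accordingly estimated at 12000 nM, within 4000 nM to 40000 nM.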

Compound 3, half-maximal inhibitory concentration: > 40000 nM
Compound 3 gave a limit, no number; the forecaster's own chance of this, stated with the estimate: 25%; at least 3.3-fold (0.52 log units) between middle value and limit.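

In this assay, nitro in place of hydrogen on an aromatic carbon, ortho to a fused ring and meta to a fused ring, gives an at least 2.5-fold higher number from compound 2 to compound 3 (0.39 log units; beyond the scatter), a step beyond the scatter towards weaker inhibition. This carbon is therefore not indifferent to substitution in this series. Compound 3 gives a limit and not a number, so the step has a lower bound only: the limit of > 40000 nM in this assay, at which 2 of the 3 values shown sit.

The compounds shown leave open how far the loss extends. They also leave open whether an amine or a methoxy group on the same carbon would produce a comparable step, or whether the step is specific to nitro.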